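The compounds below may be only part of what the source reports. "The series", "measured", "known", "first", "only" and "open" are said of these compounds alone.

Values in an ADME assay on HCT-116 cells (Homo sapiens) for cytotoxicity, read by CellTiter-Glo, with a stated time of 72 h (a lower number here means a stronger inhibitor, a higher number a weaker inhibitor), each one a limit of the assay and not a number:

Compound 1 `COc1cccc(S(=O)(=O)N2CCC(N3CCC(C)CC3)CC2)c1`: > 5000 nM
Compound 2 `CC1CCN(C2CCN(S(=O)(=O)c3cccc(-c4ccc(Cl)cc4)c3)CC2)CC1`: > 5000 nM
Compound 3 `CC1CCN(C2CCN(S(=O)(=O)c3cccc(-c4ccccc4)c3)CC2)CC1`: > 5000 nM

Compound 3 is known only through its limit, and the two other measured compounds share that limit, as the limit of > 5000 nM in this assay, at which 3 of the 3 values shown sit, shows. Compound 4 `Cc1cc(C)cc(-c2cccc(S(=O)(=O)N3CCC(N4CCC(C)CC4)CC3)c2)c1` has 3,5-dimethylphenyl in place of phenyl on an aromatic carbon, meta to a large group (3,5-dimethylphenyl in place of phenyl on an aromatic carbon). Among the compounds with values here, three measured steps bear on this change: a step that the two limits leave unreadable from compound 1 to compound 3, a step that the two limits leave unreadable from compound 1 to compound 2 and a step that the two limits leave unreadable from compound 2 to compound 3 in turn. None of them has a readable size, so they offer no measured direction for the new change. No step beyond the scatter is therefore expected in this assay, and compound 4 is likely to report a limit as well. The estimated step is a step that the limit leaves unreadable from compound 3 to compound 4 and should be read with that limit in mind. Compound 4 is estimated at 7000 nM with an expected range of 3000 nM to 20000 nM in this assay.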

Compound 4, half-maximal inhibitory concentration: > 5000 nM
Compound 4 ended at the assay's limit; the forecaster's own chance of this, stated with the estimate: 85%; the middle value does not contradict the limit.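

In this assay compound 4 also ended at a limit of the assay, so the steps to it from compound 1, compound 2 and compound 3 cannot be read: the limit of > 5000 nM in this assay, at which 4 of the 4 values shown sit.

The compounds shown leave open how large any of these changes is, and whether any group at this place gives a readable number.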